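The compounds below may be only part of what the source reports. "The series", "measured", "known", "first", "only" and "open" are said of these compounds alone.

Of the compounds shown here, three have been tested so far in an assay on isolated protein for inhibition of proto-oncogene tyrosine-protein kinase receptor Ret (Homo sapiens), read by radiometric assay and 33P incorporation, in the presence of a further agent that is not named here; a lower number here means a stronger inhibitor, a higher number a weaker inhibitor. Compound 1 `CC(C)(O)Cn1nc(-c2cc(C3CC3)on2)c2c(N)ncnc21` gives 68 nM. Compound 3 `CC(C)n1nc(-c2cc(-c3ccccc3)on2)c2c(N)ncnc21` gives 190 nM, and compound 2 `CC(C)n1nc(/C=N/OCc2ccccc2)c2c(N)ncnc21` gives 8330 nM. Among these, compound 1 gives the lowest number, and its gaps to both compound 3 and compound 2 lie beyond the usual scatter of repeated measurements, so compound 1 is the strongest inhibitor of the three.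

The next compound, compound 4 `Nc1ncnc2c1c(-c1cc(C3CC3)on1)nn2C1CCOCC1`, differs from compound 1 in one place: oxan-4-yl in place of 2-hydroxy-2-methylpropyl on an aromatic nitrogen. Among the compounds with values here, nothing among the measured compounds shows a change of this kind, so there is no directly comparable step to lean on. A modest weakening is expected because compound 1 gives 68 nM, the lowest number seen, while carrying the 2-hydroxy-2-methylpropyl group that is lost, whereas the incoming oxan-4-yl keeps only one hydrogen-bond acceptor and no donor. The step from compound 1 to compound 4 is estimated as a 1.6-fold higher number from compound 1 to compound 4 (0.21 log units; within the scatter). For compound 4 the estimated value in this assay is 110 nM, within a range of 35 nM to 350 nM.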

Compound 4, half-maximal inhibitory concentration: 5 nM
For compound 4 the middle estimate is 22-fold (1.34 log units) above the measured one; measured number below the stated range.
By their numbers in this assay, from the lowest: compound 4; then compound 1; then compound 3; then compound 2.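

In this assay, putting oxan-4-yl in place of 2-hydroxy-2-methylpropyl on the aromatic nitrogen gives a 14-fold lower number from compound 1 to compound 4 (1.13 log units; beyond the scatter), a large step beyond the scatter. The group on this nitrogen can therefore shift the number substantially while the rest of the molecule stays the same. The hydrogen-bond donor of the leaving group is also not required for a low number in this series, as oxan-4-yl has none.

This single change both removes that donor and brings in a six-membered non-aromatic ring, so the compounds shown cannot separate the two, and a cyclohexyl ring or a piperidin-4-yl ring with its amine nitrogen would test whether the ring oxygen matters. What lies behind the size of this step also stays open, as no supporting measurement is available to explain it.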